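The source may hold more compounds than are shown below. What is called first, only, known or untested is meant among the compounds shown, and "the series" means these compounds.

Measured so far in a functional assay on SNB-19 cells (Homo sapiens) for cytotoxicity, read by sulforhodamine B assay, with a stated time of 48 h, tested at 1 uM; a higher number here means a weaker effect of the compound at the concentration tested, a lower number a stronger effect:

compound 1 `Cc1cc(O)cc(-c2nn(CC#N)cc2-c2ccnc(-c3ccc(Oc4ccccc4)cc3)c2)c1` — 55%
compound 2 `COc1cc(C)cc(-c2nn(CC#N)cc2-c2ccnc(-c3ccc(N(C)C)cc3)c2)c1` — 19%

Of these two, compound 2 gives the lowest number, and its value sits far enough below that of compound 1 to lie beyond the usual scatter of repeated measurements; within these two results it therefore shows the stronger effect.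

The next compound to be tested is compound 3 `Cc1cc(O)cc(-c2nn(CC#N)cc2-c2ccnc(-c3ccc(N(C)C)cc3)c2)c1`. It differs from compound 2 in one place: hydrogen in place of methyl on an oxygen on an aromatic ring. Compound 2 and compound 3 share the dimethylamino group on the outer ring, so the change is confined to the 3-methoxy-5-methylphenyl part becoming 3-hydroxy-5-methylphenyl.

For the measured compounds named here, no pair of already measured compounds differs by exactly this change, so there is no direct step to lean on. The expectation is that the step from compound 2 to compound 3 in this assay, a number 11 percentage points higher from compound 2 to compound 3 (beyond the scatter), is small and could fall either way, most likely staying near the scatter or drifting a little upward.

On that basis compound 3 is estimated to give about 30%, with a plausible range from 10% to 60%.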

Compound 3, a percentage reported as activity, at one concentration (the size of the read-out at that concentration, not a potency): 28%
Compound 3: the middle estimate sits 2 percentage points above what was measured; measured number inside the range.
By their numbers in this assay, from the lowest: compounds 2 and 3 (each within the scatter of the next); then compound 1.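

In this assay, replacing methoxy with hydroxy on the 3-methoxy-5-methylphenyl part while the dimethylamino group stays fixed gives a number 9 percentage points higher from compound 2 to compound 3 (within the scatter), so at this position, removing the methyl from the oxygen produces no difference that can be told apart from the usual scatter. Compound 3 also makes the earlier contrast easier to read: compound 1 and compound 2 differ in two places, whereas with hydroxy held constant, dimethylamino in place of phenoxy on an aromatic carbon gives a number 27 percentage points lower from compound 1 to compound 3 (beyond the scatter), a step beyond the scatter that isolates this single change. No supporting measurement is available to explain either step.

The compounds shown leave open whether a longer chain on the same oxygen, such as ethoxy, would also stay within the scatter of compound 2 and compound 3. They also leave open whether another amine on the aromatic carbon, such as methylamino or diethylamino, would keep the stronger effect seen with dimethylamino, and whether the phenoxy step would be of similar size with methoxy in place of hydroxy.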